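A few compounds are considered here, and "the series" means these few. Any claim that something is new, unique, unknown or untested is made for them only; others in the source may bear on it.

Compound 1 `CCc1cccc(NC(=O)CN2CCC(c3cccc[n+]3[O-])CC2)c1` was tested in a functional assay on HEK293 cells for agonist activity at D(4) dopamine receptor (Homo sapiens), read by FLIPR (on this read-out lower numbers stand for smaller maximal responses and higher numbers for larger maximal responses), and compound 1 gives 62% there. For the measured compounds named here, only one other compound has been measured: compound 2 `O=C(NCN1CCC(c2cccc[n+]2[O-])CC1)c1ccccc1` gives 63% in this assay, and the two numbers lie within the usual scatter of each other, so neither compound stands apart. Compound 3 `Cc1cc(C)cc(NC(=O)CN2CCC(c3cccc[n+]3[O-])CC2)c1` has not yet been measured. Compared with compound 1 it differs in a single place: 3,5-dimethylphenyl in place of 3-ethylphenyl on an amide-type nitrogen. Going by the values given here, no measured pair shows a change of this kind, so the expectation rests on compound 1 alone, and the step is expected to stay within the scatter, no change at the digits printed from compound 1 to compound 3 (within the scatter). Compound 3 is therefore expected to reach about 62%, with a range from 48% to 76%.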

Compound 3, largest response reached (reported as efficacy), in percent of the reference or control that the assay uses: 76%
Estimate against measurement, compound 3: 14 percentage points below; the range from low to high includes it.
By their numbers in this assay, from the lowest: compounds 1 and 2 (each within the scatter of the next); then compound 3.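

Swapping 3-ethylphenyl for 3,5-dimethylphenyl on the amide-type nitrogen keeps the same atoms, joined differently, yet the maximal response rises by a number 14 percentage points higher from compound 1 to compound 3 (beyond the scatter) in this assay. For the compounds shown here, the earlier compounds showed no step at this position, so this is the first sign that the response depends on how these carbons are arranged. Nothing available here explains the rise. Still open, from the compounds shown here alone, is whether a single methyl group, a longer chain such as propyl, or a methoxy group on this phenyl would do the same.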